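Fluoro for methoxy on the anilino ring of compound 1

A few compounds are considered here, and "the series" means these few. Any claim that something is new, unique, unknown or untested is made for them only; others in the source may bear on it.

Compound 1 `COc1cccc(NC2=CC(=O)c3c(nc4n3[C@H]3OC[C@@H](O)[C@H]3OC4)C2=O)c1`: in a functional assay on HeLa cells (Homo sapiens) for inhibition, read by sulforhodamine B assay (on this read-out higher numbers stand for weaker inhibition and lower numbers for stronger inhibition), compound 1 gives > 8000 nM, which is a limit of the assay and not a number.
Compound 2 `CCCc1ccc(NC2=CC(=O)c3c(nc4n3[C@H]3OC[C@@H](O)[C@H]3OC4)C2=O)cc1`: in this assay compound 2 gives 6030 nM.
Compound 3 `Cc1ccc(NC2=CC(=O)c3c(nc4n3[C@H]3OC[C@@H](O)[C@H]3OC4)C2=O)cc1C`: in this assay compound 3 gives 4320 nM.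

Compound 1 stands at the limit of this assay, as the limit of > 8000 nM in this assay, at which 1 of the 3 values shown sits, shows, while the other two compounds give numbers. Compound 4 `O=C1C(Nc2cccc(F)c2)=CC(=O)c2c1nc1n2[C@H]2OC[C@@H](O)[C@H]2OC1` differs from compound 1 by fluoro in place of methoxy on an aromatic carbon. The measured steps that bear on this change both start from compound 1: an at least 1.3-fold lower number from compound 1 to compound 2 (0.12 log units; that floor lies within the scatter) and an at least 1.8-fold lower number from compound 1 to compound 3 (0.26 log units; that floor lies within the scatter), and neither floor reaches beyond the scatter. The step between the two measured numbers, a 1.4-fold lower number from compound 2 to compound 3 (0.14 log units; within the scatter), also stays within the scatter. Going by the values given here, no measured step swaps the methoxy for a fluoro, so the expectation rests only on the observation that every compound with a number sits in the same high range of this assay. Compound 4 is therefore expected to give 8000 nM, within 3000 nM to 25000 nM, with a fair chance that only a limit is reported again. That estimate means a number no higher from compound 1 to compound 4 (the limit leaves the size open), a step expected to remain within the scatter.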

Compound 4, half-maximal inhibitory concentration: > 8000 nM
Compound 4: only a limit was reported; the forecaster's own chance of this, stated with the estimate: 50%; the middle value sits exactly at the limit.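

In this assay, fluoro in place of methoxy on this aromatic ring leaves the compound at a limit of the assay and not at a number, so the series now holds a second compound without a measurable value: the limit of > 8000 nM in this assay, at which 2 of the 4 values shown sit. The step between compound 1 and compound 4 cannot be read, as both give only limits. The two readable steps are an at least 1.8-fold higher number from compound 3 to compound 4 (0.26 log units; that floor lies within the scatter) and an at least 1.3-fold higher number from compound 2 to compound 4 (0.12 log units; that floor lies within the scatter), so neither floor separates compound 4 from the compounds with numbers.

From the compounds shown here alone, whether the true values of compound 1 and compound 4 differ stays open. So does whether an amine, a carboxylic acid or a chain longer than propyl on this ring would give a number clearly lower than those of compound 2 and compound 3.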